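The source may hold more compounds than are shown below. What is called first, only, known or untested is meant among the compounds shown, and "the series" means these compounds.

Of the compounds shown here, two share the same core and have been tested in a functional assay on ECV-304 cells (Homo sapiens), read by MTT assay, with stated times of 24 h and 12 h, tested at 50 uM; a higher number here means a stronger effect of the compound at the concentration tested, a lower number a weaker effect. Compound 1 `Cc1nc(C)c(COc2ccccc2C(=O)O)nc1C` gives 18.2% in this assay. Among the measured compounds shown here, compound 2 `Cc1nc(C)c(CSc2nnc(-c3cccs3)n2N)nc1C` gives 38.2% in this assay, and with that number compound 2 stands highest of the two values measured so far; its only neighbour, compound 1, lies lower by a gap that is beyond the usual scatter of such measurements. The next compound, compound 3 `Cc1nc(C)c(CSc2nnc(-c3ccco3)n2N)nc1C`, has not yet been measured. It differs from compound 2 in a single place: furan-2-yl in place of thiophen-2-yl on an aromatic carbon. For the measured compounds named here, no pair of measured compounds that differ in just one place is available, so there is no measured step of this kind to lean on; the expectation rests only on how small the change is. The step from compound 2 to compound 3 is expected to be a number 3.2 percentage points lower from compound 2 to compound 3 (within the scatter), which would fall within the usual scatter in this assay. Compound 3 is therefore estimated to give 35% in this assay, with a range from 20% to 50%.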

Compound 3, a percentage reported as activity, at one concentration (the size of the read-out at that concentration, not a potency): 23.5%
Beside the measured number, compound 3's estimate is 11.5 percentage points above it; the measured number falls inside the stated range.
By their numbers in this assay, from the lowest: compounds 1 and 3 (each within the scatter of the next); then compound 2.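

Within this assay, swapping thiophen-2-yl for furan-2-yl gives a number 14.7 percentage points lower from compound 2 to compound 3 (beyond the scatter). Among the compounds shown here, this is the first measured step, and it shows that this place, on an aromatic carbon of a five-membered aromatic ring with 3 nitrogen, responds to a very small change: the two groups match in heavy atoms, hydrogen-bond donors, hydrogen-bond acceptors and charge, and differ only in having sulfur or oxygen in the ring. Nothing measured here explains why the read-out moves with this swap, so the step stands as an observation without a known cause.

The compounds shown leave open how a phenyl ring, a pyridine ring or a plain methyl group would read at this place, and so whether the step from thiophen-2-yl to furan-2-yl is part of a wider trend or a single case. From the compounds shown here alone, compound 2 and compound 3 also both keep the amino group on the neighbouring ring atom, so it remains open whether the same swap would give a similar step with a hydrogen or a methyl group there instead.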